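A few compounds are considered here, and "the series" means these few. Any claim that something is new, unique, unknown or untested is made for them only; others in the source may bear on it.

Measured so far in a physicochemical assay for solubility, in phosphate buffer, at pH 7.4; a lower number here means a less soluble compound, a higher number a more soluble compound:
- compound 1 `CC(=O)N[C@@H]1CCC[C@H](C(=O)Nc2cc(-c3cnn(C)c3C)c(Cl)cn2)C1` gives 960000 nM
- compound 2 `CC(=O)N[C@@H]1CCC[C@H](C(=O)Nc2cc(-c3cnn4c3COCC4)c(Cl)cn2)C1` gives 220000 nM

Of these two numbers, compound 2 holds the lower, a position beyond the scatter from the other. The next structure, compound 3 `CC(=O)N[C@@H]1CCC[C@H](C(=O)Nc2cc(-c3cnn4c3NCCC4)c(Cl)cn2)C1`, keeps the shared core and changes only the group on the aromatic carbon opposite the ring nitrogen: a group of 9 heavy atoms (6 carbon, 3 nitrogen; one five-membered aromatic ring with 2 hetero atoms, one six-membered non-aromatic ring with 2 hetero atoms) in place of a group of 9 heavy atoms (6 carbon, 2 nitrogen, 1 oxygen; one five-membered aromatic ring with 2 hetero atoms, one six-membered non-aromatic ring with 2 hetero atoms), on an aromatic carbon. Within the data shown here, only one measured step bears on this, and only indirectly. That step, a 4.4-fold lower number from compound 1 to compound 2 (0.64 log units; beyond the scatter), was modest, and it brought in the two-ring group that now leaves. Among the measured compounds shown here, no measured pair shows the present exchange, so compound 2 at 220000 nM serves as the anchor for this assay. A slight fall is expected, not one clearly beyond the scatter, and the estimated step is a 1.4-fold lower number from compound 2 to compound 3 (0.14 log units; within the scatter). For compound 3 the expected value is 160000 nM, with an estimated range from 55000 nM to 450000 nM.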

Compound 3, solubility: 860000 nM
The estimate for compound 3 lay 5.4-fold (0.73 log units) below the measured number, outside the stated range (above it).
By their numbers in this assay, from the lowest: compound 2; then compounds 3 and 1 (each within the scatter of the next).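

In this assay, the two-ring group at this position need not lower the number: replacing its oxygen with a nitrogen, which adds a hydrogen-bond donor to the group, gives a 3.9-fold higher number from compound 2 to compound 3 (0.59 log units; beyond the scatter). Set against the one-ring group, the entering group gives a 1.1-fold lower number from compound 1 to compound 3 (0.05 log units; within the scatter). The earlier fall, a 4.4-fold lower number from compound 1 to compound 2 (0.64 log units; beyond the scatter), therefore belongs to the oxygen-bearing two-ring group and not to every two-ring group at this position. No measurement here accounts for the difference between the two groups. The compounds shown leave open whether the hydrogen on the ring nitrogen matters, which a methyl on that nitrogen or an all-carbon second ring would help to test.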